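The compounds below may be only part of what the source reports. "The series", "measured", "known", "first", "only" and "open" are said of these compounds alone.

Working notes on the series. In an assay on isolated protein for agonist activity at Bile acid receptor (Homo sapiens), read by AlphaScreen, with a stated time of 30 min (a lower number here means that less compound is needed, a higher number that more compound is needed for the effect), compound 1 `Cc1nn(-c2ccccc2C(F)(F)F)c2c1C(c1ccc(Oc3ccccc3)cc1)SC(C)C(=O)N2` gives 2000 nM, and compound 2 `Cc1nn(-c2ccccc2Cl)c2c1C(c1ccc(Oc3ccccc3)cc1)SC(C)C(=O)N2` gives 2700 nM. Among the compounds with values here, the only single-point step measured so far, chloro in place of trifluoromethyl on an aromatic carbon, reads a 1.4-fold higher number from compound 1 to compound 2 (0.13 log units; within the scatter). Compound 3 `Cc1ccccc1-n1nc(C)c2c1NC(=O)[C@H](C)S[C@@H]2c1ccc(-c2ccc(C(=O)O)cc2)cc1`, which carries a different aryl group on the shared core, is recorded as "not active" (no number reported) with no number reported. Compound 2 therefore holds the highest of the two numbers in this assay, with compound 1 as its nearest neighbour within the scatter, and one further entry without a number.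

Compound 4 `Cc1nn(-c2ccccc2Br)c2c1C(c1ccc(Oc3ccccc3)cc1)SC(C)C(=O)N2` differs from compound 2 by bromo in place of chloro on an aromatic carbon. Within the data shown here, the one step that bears on this change is the halogen-for-trifluoromethyl exchange at the same aromatic carbon, which from compound 1 to compound 2 stayed within the scatter. Among the measured compounds shown here, a second exchange among halogens at that carbon is expected to give no step in this assay beyond the scatter, so the expected step from compound 2 to compound 4 is no change at the digits printed from compound 2 to compound 4 (within the scatter). Compound 4 is accordingly expected to give 2700 nM, within 1300 nM to 5500 nM.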

Compound 4, half-maximal effective concentration: 1800 nM
The estimate for compound 4 lay 1.5-fold (0.18 log units) above the measured number, and the stated range covers the measured number.
By their numbers in this assay, from the lowest: compounds 4, 1 and 2 (each within the scatter of the next).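

In this assay, bromo in place of chloro on this aromatic carbon gives a 1.5-fold lower number from compound 2 to compound 4 (0.18 log units; within the scatter), and bromo in place of trifluoromethyl gives a 1.1-fold lower number from compound 1 to compound 4 (0.05 log units; within the scatter), so both steps stay within the scatter. Together with the earlier step, a 1.4-fold higher number from compound 1 to compound 2 (0.13 log units; within the scatter), this compares chloro, bromo and trifluoromethyl pairwise at one position, and no pair separates beyond the scatter. Nothing on hand bears on why these three groups read alike here.

From the compounds shown here alone, whether a group of another kind on this carbon, such as an amine or a nitrile, would move the number beyond the scatter remains open. Compound 3 differs from the others in more than one place, so its entry cannot be read as a step at this position.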